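Trifluoromethyl in place of methyl on a para-substituted phenyl triazole

A few compounds are considered here, and "the series" means these few. Any claim that something is new, unique, unknown or untested is made for them only; others in the source may bear on it.

Of the compounds shown here, two of one series have been measured for antiproliferative activity in a functional assay on B16-F10 cells (Mus musculus) for antiproliferative activity, read by MTT assay, with a stated time of 72 h; on this read-out lower numbers stand for stronger inhibition and higher numbers for weaker inhibition. Compound 1 `COc1ccc(-c2cn(Cc3ccccc3)nn2)cc1` carries a methoxy group; in this assay compound 1 gives 88500 nM. Compound 2 `Cc1ccc(-c2cn(Cc3ccccc3)nn2)cc1` carries a methyl group in its place, and in this assay compound 2 gives 66400 nM. Going by the values given here, the step of a 1.3-fold lower number from compound 1 to compound 2 (0.12 log units; within the scatter) is the only measured step so far. Compound 2 therefore stands at the lowest of the two numbers, but its nearest neighbour compound 1 lies within the scatter of it, so no order between the two can be claimed.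

Compound 3 `FC(F)(F)c1ccc(-c2cn(Cc3ccccc3)nn2)cc1` is not yet measured. It differs from compound 2 by trifluoromethyl in place of methyl on an aromatic carbon. Among the compounds with values here, the one measured step, from methoxy to methyl at this place, stayed within the scatter, so no measured step indicates a change beyond the scatter for the present exchange. The number for compound 3 in this assay is therefore expected to stay near that of compound 2, with the estimated step of a 1.2-fold lower number from compound 2 to compound 3 (0.08 log units; within the scatter). Compound 3 is estimated at 55000 nM, within a range from 15000 nM to 150000 nM.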

Compound 3, half-maximal inhibitory concentration: 35400 nM
Estimate against measurement, compound 3: 1.6-fold (0.19 log units) above, within the range that was stated.
By their numbers in this assay, from the lowest: compounds 3, 2 and 1 (each within the scatter of the next, the first and the last beyond it).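

In this assay, trifluoromethyl in place of methyl gives a 1.9-fold lower number from compound 2 to compound 3 (0.27 log units; within the scatter), so this exchange alone sets no order between the two compounds. Trifluoromethyl in place of methoxy, however, gives a 2.5-fold lower number from compound 1 to compound 3 (0.40 log units; beyond the scatter), the only step among the three compounds that lies beyond the scatter, and so the first sign that the group on this aromatic carbon, para to a large group, can alter the number, if only modestly. No measurement shown here accounts for that difference.

As far as these compounds go, the three compounds cover only methoxy, methyl and trifluoromethyl at this place, so it remains open whether an amine, a carboxylic acid or a longer chain there would give a number close to these or a clearly different one. All three also share the rest of the core unchanged, which leaves open what a change elsewhere in it would do, and whether such a change would add to the modest step seen here or leave it as it stands.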